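Nitro-to-methoxy swap on the ring-nitrogen benzyl arm

A few compounds are considered here, and "the series" means these few. Any claim that something is new, unique, unknown or untested is made for them only; others in the source may bear on it.

Measured compounds in a functional assay on SH-SY5Y cells (Homo sapiens) for cytotoxicity, read by MTT assay, with stated times of 8 h, 30 min and 12 h, tested at 0.05 uM; a higher number here means a stronger effect of the compound at the concentration tested, a lower number a weaker effect:
compound 1, `COc1ccc(CNC(=N)[C@@H]2CCC(=O)N2Cc2ccccc2[N+](=O)[O-])cc1`, gives 18.1%
compound 2, `N=C(NCc1ccccc1)[C@@H]1CCC(=O)N1Cc1ccc([N+](=O)[O-])cc1`, gives 13.7%
compound 3, `COc1ccc(CNC(=N)[C@@H]2CCC(=O)N2Cc2ccc([N+](=O)[O-])cc2)cc1`, gives 14.3%

Compound 3 stands second of the three numbers, with compound 2 nearest and compound 1 furthest; both gaps lie within the scatter, so the three compounds are indistinguishable on this assay.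

Compound 4, `COc1ccc(CNC(=N)[C@@H]2CCC(=O)N2Cc2ccc(OC)cc2)cc1`, is not yet measured. Its difference from compound 3 is methoxy in place of nitro on an aromatic carbon, so on the benzyl arm on the ring nitrogen the 4-nitrophenyl of compound 3 becomes 4-methoxyphenyl.

Going by the values given here, two measured steps bear on it. Moving the nitro group, a number 3.8 percentage points lower from compound 1 to compound 3 (within the scatter), changed nothing beyond the scatter. Adding a methoxy group on the other aryl ring, a number 0.6 percentage points higher from compound 2 to compound 3 (within the scatter), likewise changed nothing beyond the scatter. Among the compounds with values here, neither is the present exchange, and no measured pair replaces nitro by methoxy, but both show that changes of this kind on either benzyl arm left this assay flat. The step of a number 0.3 percentage points lower from compound 3 to compound 4 (within the scatter) is therefore expected to lie within the scatter, with no direction preferred.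

The value for compound 4 is estimated at 14%, with a range of 6% to 22%.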

Compound 4, a percentage reported as activity, at one concentration (the size of the read-out at that concentration, not a potency): 24.2%
Estimate against measurement, compound 4: 10.2 percentage points below; the measured number lies above the stated range.
By their numbers in this assay, from the lowest: compounds 2, 3, 1 and 4 (each within the scatter of the next, the first and the last beyond it).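

In this assay, exchanging nitro for methoxy on the aromatic carbon para to a large group gives a number 9.9 percentage points higher from compound 3 to compound 4 (within the scatter); this is the largest step read on this arm, yet it stays inside the scatter, so the nitro group is shown to be replaceable here without a change that can be told from noise. The comparison with the 2-nitrophenyl arm gives the same reading, a number 6.1 percentage points higher from compound 1 to compound 4 (within the scatter), so the three aryl arms on the ring nitrogen, 2-nitrophenyl, 4-nitrophenyl and 4-methoxyphenyl, cannot be separated in this read-out, and both steps into compound 4 point the same way without either one establishing a real rise. No measurement bears on what lies behind these numbers, and nothing can be said of the reason for the size of either step.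

As far as these compounds go, whether an amine or a carboxylic acid on this aromatic carbon would carry the read-out beyond the scatter remains open. Also open, from the compounds shown here alone, is whether the steps into compound 4 would hold up at other concentrations, since a single concentration gives the size of the read-out there and no potency.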